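A few compounds are considered here, and "the series" means these few. Any claim that something is new, unique, unknown or untested is made for them only; others in the source may bear on it.

Measured compounds:
- compound 1, `CC1=C(C(=O)OC(C)(C)C)C(c2cccs2)NC(=O)N1`: 38%
- compound 2, `CC1=C(C(=O)OC(C)(C)C)C(c2cccs2)NC(=O)N1C`: 24%

Both compounds were tested in an assay on membranes from HEK293 cells for displacement of a labelled ligand from adenosine receptor A2b (Homo sapiens), read by scintillation counting, with a stated time of 30 min, tested at 1 uM; a higher number here means more inhibition at the concentration tested (going by the name of the read-out), a lower number less inhibition. Compound 1 gives 38% and stands highest of the two numbers; its nearest neighbour is compound 2, which gives 24%. Among the compounds with values here, the only measured step, a number 14 percentage points lower from compound 1 to compound 2 (beyond the scatter), comes from a methyl in place of hydrogen on an amide-type nitrogen in a ring, and it lowered the read-out beyond the scatter.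

The unmeasured compound 3, `CC1=C(C(=O)C2CC2)C(c2cccs2)NC(=O)N1`, differs from compound 1 in another place: cyclopropyl in place of tert-butoxy on a carbonyl carbon. Within the data shown here, the one measured step concerns the ring nitrogen and does not touch the carbonyl carbon, so no measured step bears on this change. The data give no guide to its direction or size, and the expectation therefore rests on compound 1 alone, with a wide range around it.

On that basis, compound 3 is expected to give 33%, within 10% to 55%. This estimate means a step of a number 5 percentage points lower from compound 1 to compound 3 (within the scatter) in this assay, expected to stay within the scatter.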

Compound 3, a percentage reported as inhibition, at one concentration (the size of the read-out at that concentration, not a potency): 1%
The estimate for compound 3 lay 32 percentage points above the measured number; measured number below the stated range.
By their numbers in this assay, from the lowest: compound 3; then compound 2; then compound 1.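

Within the data shown here, this is the first look at the carbonyl carbon, and in this assay the change there is large: cyclopropyl in place of tert-butoxy gives a number 37 percentage points lower from compound 1 to compound 3 (beyond the scatter) while the methyl on the ring nitrogen gave the modest a number 14 percentage points lower from compound 1 to compound 2 (beyond the scatter) in the same series. So the group on the carbonyl carbon has a strong hold on this read-out, and with compound 3 at 1% the swap leaves almost no inhibition at the concentration tested. The swap alters several things at once, since a larger open group with an oxygen leaves and a smaller three-membered carbon ring enters, and nothing measured here says which of these accounts for the drop.

Still open, going by these compounds, is whether the oxygen or the size of the group counts more: a tert-butyl group, which keeps the branched carbons without the oxygen, and a cyclopropoxy group, which keeps the ring and restores the oxygen, would pull those two apart. Also open, on these data alone, is how a methoxy group, an ethoxy group or an amine would fare on the same carbonyl carbon, and whether any group there could rise beyond compound 1.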